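The source may hold more compounds than are shown below. What is called first, only, known or untested is meant among the compounds shown, and "the series" means these compounds.

Measured compounds:
- compound 1, `Cc1cccc(/C=C2\CCC/C(=C\c3ccccc3)C2=O)c1`: 47.9%
- compound 2, `O=C(C1=C(O)/C(=C/c2cccc(O)c2)CCC1)c1ccccc1`: 43.2%
- compound 3, `O=C(/C=C(O)/C=C/c1ccc(O)c(O)c1)c1cc(Cl)ccc1O`: 85.6%

All three compounds were tested in an assay on isolated protein for inhibition of Alpha glucosidase (Homo sapiens), with stated times of 5 min and 15 min, tested at 50 uM; on this read-out lower numbers stand for less inhibition and higher numbers for more inhibition at the one concentration tested (going by the name of the read-out). Among the three numbers, compound 1 stands second highest. Its nearest neighbour is compound 2, whose value lies within the usual scatter of compound 1, so the two cannot be told apart on this read-out. Compound 3 lies far above, beyond the scatter, and it is built on a quite different core, so it tells little about small changes to the core of compound 1.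

Compound 4, `O=C1/C(=C/c2ccccc2)CCC/C1=C\c1ccc(Cl)cc1`, has not yet been measured in this assay. It differs from compound 1 in one place: 4-chlorophenyl in place of 3-methylphenyl on a double-bonded chain carbon bound to a double-bonded ring carbon. Among the compounds with values here, both the leaving and the entering group are small aromatic rings with no hydrogen-bond donors or acceptors, and no step between two measured compounds shows what such a swap does on this core. On that basis the step is expected to be small, in no particular direction, and not beyond the scatter, so that the expected step from compound 1 to compound 4 is a number 2.1 percentage points higher from compound 1 to compound 4 (within the scatter). Compound 4 is therefore estimated to give about 50%, most likely between 35% and 65%, close to the value of compound 1 at 47.9%.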

Compound 4, a percentage reported as inhibition, at one concentration (the size of the read-out at that concentration, not a potency): 27.6%
Estimate against measurement, compound 4: 22.4 percentage points above; measured number below the stated range.
By their numbers in this assay, from the lowest: compound 4; then compounds 2 and 1 (each within the scatter of the next); then compound 3.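

In this assay, putting 4-chlorophenyl in place of 3-methylphenyl on a double-bonded chain carbon bound to a double-bonded ring carbon gives a number 20.3 percentage points lower from compound 1 to compound 4 (beyond the scatter). Within the data shown here, this is the first single-place comparison on the shared core, and it shows that this position is not indifferent to what the ring carries, even though both groups have the same count of heavy atoms and neither has a hydrogen-bond donor or acceptor. Nothing measured here accounts for the drop in inhibition.

The swap changes two things at once, the ring's substituent (methyl against chlorine) and its place on the ring, as the names 3-methylphenyl and 4-chlorophenyl show, and the compounds shown cannot separate the two. They also leave open how inhibition at this position would respond to a phenyl ring carrying an amine or a carboxylic acid, or to a longer chain in place of the ring.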